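This account rests on a few compounds, and the source may have more. Where it says the series, first, only, none or still open, it means among the compounds named here.

Measured so far in an assay for inhibition of Maternal embryonic leucine zipper kinase (Homo sapiens), read by ADP-Glo, with a stated time of 0.5 h; a higher number here means a weaker inhibitor, a lower number a stronger inhibitor:
- compound 1 `CC(C)Nc1sc(C(=O)c2ccncc2)c(N)c1C#N`: > 5000 nM
- compound 2 `CC(C)Nc1sc(C(=O)c2cccnc2)c(N)c1C#N`: > 5000 nM
- compound 3 `CC(C)Nc1sc(C(=O)c2ccco2)c(N)c1C#N`: 1350 nM

The value given for compound 1 is a limit of this assay, not a number. The value given for compound 2 is likewise a limit. Going by the values given here, compound 3 is therefore the only member of the series with a read number in this assay; the other two values shown are limits (the limit of > 5000 nM in this assay, at which 2 of the 3 values shown sit). The measured steps of an at least 3.7-fold lower number from compound 1 to compound 3 (0.56 log units; beyond the scatter) and an at least 3.7-fold lower number from compound 2 to compound 3 (0.56 log units; beyond the scatter) both run toward compound 3; the step that the two limits leave unreadable from compound 1 to compound 2 cannot be read.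

Compound 4 `CC(C)Nc1sc(C(=O)c2ccc(Cl)s2)c(N)c1C#N` differs from compound 3 in one place: 5-chlorothiophen-2-yl in place of furan-2-yl on a carbonyl carbon. Among the compounds with values here, no measured step bears directly on this exchange; the only steps known concern the move from a pyridyl to the furan-2-yl group, which improved the number. Against that background, a step of no more than modest size in either direction is expected for a 1.7-fold lower number from compound 3 to compound 4 (0.23 log units; within the scatter). For compound 4 a value of about 800 nM is estimated, with a likely range from 200 nM to 3500 nM.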

Compound 4, half-maximal inhibitory concentration: 192 nM
Estimate against measurement, compound 4: 4.2-fold (0.62 log units) above; the measured number lies below the stated range.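

In this assay, the exchange of one five-membered aromatic ring for another at this place on the carbonyl carbon gives a 7.0-fold lower number from compound 3 to compound 4 (0.85 log units; beyond the scatter), so this position separates five-membered aromatic rings from each other and not only from the pyridyl groups. Against those pyridyl groups, the same 5-chlorothiophen-2-yl group gives an at least 26-fold lower number from compound 2 to compound 4 (1.41 log units; beyond the scatter) and an at least 26-fold lower number from compound 1 to compound 4 (1.41 log units; beyond the scatter), which widens the spread seen at this position. Compound 1 and compound 2 each carry a limit and not a number, so these two steps fix only a minimum size: the limit of > 5000 nM in this assay, at which 2 of the 4 values shown sit.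

The exchange changes the ring oxygen to sulfur and adds chlorine together, so the share of each stays unresolved. Unsubstituted thiophen-2-yl, or 5-chlorofuran-2-yl, would separate the two changes, and 5-bromothiophen-2-yl or 5-methylthiophen-2-yl would test what the chlorine position accepts.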